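The source may report more compounds than this note shows. Statements on the series, on what has been measured and on what is new or still open speak of the compounds shown alone.

Compound 1, `COc1ccc(CSc2nc(Cc3cc(C)cc(C)c3)c(C)c(=O)[nH]2)cc1`, and compound 2, `Cc1cc(C)cc(Cc2nc(SCc3ccc([N+](=O)[O-])cc3)[nH]c(=O)c2C)c1`, share a core and differ in one place: nitro in place of methoxy on an aromatic carbon. In an ADME assay on MT4 cells (Homo sapiens) for cytotoxicity, read by MTT assay (a lower number here means that less compound is tolerated, a higher number that more compound is tolerated), compound 1 gives > 329000 nM, a limit of the assay rather than a number. In this assay compound 2 gives > 316000 nM, likewise only a limit. The step that the two limits leave unreadable from compound 1 to compound 2 therefore cannot be read, because the limit of > 329000 nM in this assay, at which 1 of the 3 values shown sits, and the limit of > 316000 nM in this assay, at which 1 of the 3 values shown sits, cap both values.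

Compound 3, `CCc1c(Cc2c(Cl)cccc2Cl)nc(SCc2ccc(OC)cc2)[nH]c1=O`, carries a different core; the difference between the two cores and the core of compound 1 is not broken down here. In this assay compound 3 gives > 287000 nM, again a limit and not a number, as the limit of > 287000 nM in this assay, at which 1 of the 3 values shown sits, records.

Compound 4, `CCc1c(Cc2c(Cl)cccc2Cl)nc(SCc2ccc([N+](=O)[O-])cc2)[nH]c1=O`, is still to be measured in this assay. It relates to compound 3 as compound 2 relates to compound 1: nitro in place of methoxy on an aromatic carbon. The place of the change is the same in both pairs, so this is the same change, made twice among the compounds shown.

Since the first occurrence left no readable step, and every value shown sits at a limit, the expectation for compound 4 rests on compound 3 with > 287000 nM and on compound 2 with > 316000 nM: the step from compound 3 to compound 4 is estimated as a step that the limit leaves unreadable from compound 3 to compound 4, and compound 4 is expected to give about 300000 nM, most likely again reported only as a limit.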

Compound 4, half-maximal cytotoxic concentration: > 278000 nM
Compound 4 gave a limit, no number; the forecaster's own chance of this, stated with the estimate: 85%; the middle value is on the limit's open side.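

In this assay compound 4 gives > 278000 nM, a limit of the assay and not a number. Compound 3 also gives only a limit, and no step can be read between compound 3 and compound 4. The compounds shown leave open how much of any of the four compounds is tolerated, and whether nitro in place of methoxy changes that at all.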